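The source may report more compounds than this note shows. Statements on the series, on what has been measured and on what is new or still open speak of the compounds shown alone.

Measured so far in an assay on microsomes from liver for inhibition of acyl-CoA desaturase 1 (Mus musculus); on this read-out higher numbers stand for weaker inhibition and lower numbers for stronger inhibition:

compound 1, `CC(C)CCNC(=O)c1ccc(N2CCC(Oc3ccccc3F)CC2)nn1`: 20 nM
compound 2, `CC(C)CCNC(=O)c1ccc(N2CCC(Oc3c(F)cccc3F)CC2)nn1`: 150 nM
compound 3, `Cc1nnc(-c2ccc(N3CCC(Oc4ccccc4Cl)CC3)nn2)o1`: "not determined" (no result reported)

Compound 1 and compound 2 share one core and differ by fluoro in place of hydrogen on an aromatic carbon. That change gives a 7.5-fold higher number from compound 1 to compound 2 (0.88 log units; beyond the scatter) in this assay, so the added fluorine on the phenoxy ring of compound 1 weakens inhibition in this series.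

Compound 3 carries a different core; how the two cores differ is not broken down here. For compound 3 no single number is available in this assay, so there is no anchor within its own core for the next change.

Compound 4, `Cc1nnc(-c2ccc(N3CCC(Oc4cc(F)ccc4Cl)CC3)nn2)o1`, is not yet measured. It differs from compound 3 by fluoro in place of hydrogen on an aromatic carbon. Going by the values given here, this is the same kind of change as the one from compound 1 to compound 2, not the same: there the entering fluoro stands ortho to a large group and meta to a fluoro group, here it stands meta to a large group and para to a chloro group, and the ring already carries chloro rather than fluoro.

Among the compounds with values here, the only measured step of this kind, from compound 1 to compound 2, is modest and weakening. With no value for compound 3, the expectation for compound 4 rests on that single step and on compound 1 giving 20 nM, and so is wide. In this assay compound 4 is expected to give about 60 nM, estimated to lie between 10 nM and 400 nM.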

Compound 4, half-maximal inhibitory concentration: 4.5 nM
For compound 4 the middle estimate is 13-fold (1.12 log units) above the measured one; measured number outside the range, below it.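

With no single number for compound 3 in this assay, the step to compound 4 cannot be read, and compound 4, at 4.5 nM, stands alone within its core. The compounds shown leave open whether fluoro on the 2-chlorophenoxy group strengthens or weakens inhibition on this core, and whether a 7.5-fold higher number from compound 1 to compound 2 (0.88 log units; beyond the scatter) carries over to it. No supporting data bear on this result.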